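Changing the Ester Aryl Group When Every Reading Is a Limit

A few compounds are considered here, and "the series" means these few. Any claim that something is new, unique, unknown or untested is made for them only; others in the source may bear on it.

Compounds measured so far in a functional assay on SK-BR-3 cells (Homo sapiens) for antiproliferative activity, read by MTT assay, with a stated time of 72 h; on this read-out higher numbers stand for weaker inhibition and lower numbers for stronger inhibition:
compound 1 `C/C=C1/[C@H](O[C@@H]2O[C@H](COC(C)=O)[C@@H](OC(C)=O)[C@H](OC(C)=O)[C@H]2OC(C)=O)OC=C(C(=O)OC)[C@H]1CC(=O)O` gives > 15000 nM
compound 2 `C/C=C1/[C@H](O[C@@H]2O[C@H](CO)[C@@H](O)[C@H](O)[C@H]2O)OC=C(C(=O)OC)[C@H]1CC(=O)OCCc1ccc(OC)c(OC)c1` gives > 15000 nM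
compound 3 `C=CCOC(=O)C[C@@H]1C(C(=O)OC)=CO[C@@H](O[C@@H]2O[C@H](COC(C)=O)[C@@H](OC(C)=O)[C@H](OC(C)=O)[C@H]2OC(C)=O)/C1=C/C` gives > 20000 nM

None of these three readings is a number. For compound 1 the reading is a limit of this assay. For compound 2 the reading is likewise a limit, so compound 2 stands at the edge of what this assay can report, at the limit of > 15000 nM in this assay, at which 2 of the 3 values shown sit. For compound 3 the reading is a limit as well, at the limit of > 20000 nM in this assay, at which 1 of the 3 values shown sits. Among the measured compounds shown here, the only pair that differs in one place is compound 1 and compound 3, with allyl in place of hydrogen on an oxygen next to a carbonyl group, and that step, a step that the two limits leave unreadable from compound 1 to compound 3, cannot be read because both ends are limits.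

Compound 4 `C/C=C1/[C@H](O[C@@H]2O[C@H](CO)[C@@H](O)[C@H](O)[C@H]2O)OC=C(C(=O)OC)[C@H]1CC(=O)OCCc1ccc([N+](=O)[O-])cc1` differs from compound 2 by 4-nitrophenyl in place of 3,4-dimethoxyphenyl on a saturated chain carbon, two bonds along the chain from an oxygen next to a carbonyl group. For the measured compounds named here, no measured step touches that part of the molecule, and no measured step has a readable size at all, so there is nothing in the data to point to a shift in either direction in this assay. Compound 4 is therefore expected to give 15000 nM, within 5000 nM to 30000 nM, most likely again as a limit. The expected step is a number no higher from compound 2 to compound 4 (the limit leaves the size open).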

Compound 4, half-maximal inhibitory concentration: > 20000 nM
Compound 4 was reported as a limit (the forecaster's own chance of this, stated with the estimate: 80%); middle value at least 1.3-fold (0.12 log units) away from the limit.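

Compound 2 gives > 15000 nM, which is a limit. Compound 4 gives > 20000 nM, also a limit, so no size can be read for the step between compound 2 and compound 4. The compounds shown leave open what number any of them would reach in this assay, and whether 4-nitrophenyl in place of 3,4-dimethoxyphenyl changes inhibition at all.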